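The source may hold more compounds than are shown below. What is called first, only, known or untested is meant among the compounds shown, and "the series" means these compounds.

Of the compounds shown here, three of a shared core have been measured in a functional assay for antagonist activity at corticotropin-releasing factor receptor 1 (Rattus norvegicus); on this read-out lower numbers stand for stronger inhibition and higher numbers for weaker inhibition. Compound 1 `CC[C@H](C1CC1)n1c(=O)c(C)nc2c(-c3ccc(Cl)cc3Cl)ccnc21` gives 8.2 nM, and compound 2 `CCCC(C1CC1)n1c(=O)c(C)nc2c(-c3ccc(Cl)cc3Cl)ccnc21` gives 4.3 nM. Compound 3 `Cc1nc2c(-c3ccc(Cl)cc3Cl)ccnc2n(CC(C)C)c1=O` gives 3500 nM, the highest number of the three: a 430-fold higher number from compound 1 to compound 3 (2.63 log units; beyond the scatter) and an 810-fold higher number from compound 2 to compound 3 (2.91 log units; beyond the scatter), so compound 3 is far weaker than either of the others, while a 1.9-fold lower number from compound 1 to compound 2 (0.28 log units; within the scatter).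

Compound 4 `CC[C@@H](C1CC1)n1c(=O)c(C)nc2c(-c3ccc(Cl)cc3Cl)ccnc21` is not yet measured. It differs from compound 3 in one place: 1-cyclopropylpropyl in place of isobutyl on an aromatic nitrogen. The group that enters is the same one that compound 1 carries, differing only in the arrangement at its stereocentre.

Going by the values given here, the steps that bear on this change are the two that remove the isobutyl group in favour of a branched cyclopropyl-bearing chain, and both were large: from compound 1 to compound 3 and from compound 2 to compound 3 the numbers rose steeply. Reversing that change is therefore expected to lower the number again by a large amount. Among the compounds with values here, how close compound 4 comes to compound 1 is not settled by these data, since no pair of mirror-image compounds has been measured here, so the expected drop is taken as large but with a wide range.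

Compound 4 is expected to give 40 nM, between 6 nM and 400 nM, which would be an 88-fold lower number from compound 3 to compound 4 (1.94 log units; beyond the scatter).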

Compound 4, half-maximal inhibitory concentration: 7.4 nM
For compound 4 the middle estimate is 5.4-fold (0.73 log units) above the measured one; low and high end bracket the measured number.
By their numbers in this assay, from the lowest: compounds 2, 4 and 1 (each within the scatter of the next); then compound 3.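

Compound 4 carries the opposite arrangement at the stereocentre from compound 1, yet placing 1-cyclopropylpropyl on the aromatic nitrogen in place of isobutyl still brings a large change in this assay, with a 470-fold lower number from compound 3 to compound 4 (2.67 log units; beyond the scatter), so the large effect of this group is not tied to one configuration. The comparison of the two configurations is direct, and the step between them, a 1.1-fold lower number from compound 1 to compound 4 (0.04 log units; within the scatter), shows no readable preference at this stereocentre, a clean reading for this pair: the fact that compounds 1 and 4 differ only in the configuration as drawn The shorter and longer chains also remain indistinguishable with the new configuration, with a 1.7-fold higher number from compound 2 to compound 4 (0.24 log units; within the scatter).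

As far as these compounds go, what remains open is which feature of the entering group matters, since 1-cyclopropylpropyl differs from isobutyl in both its three-membered ring and its branching at the carbon on the nitrogen, and a group such as 1-ethylpropyl, branched but without a ring, would separate the two. Also open is whether the same indifference to configuration holds for 1-cyclopropylbutyl, whose two mirror-image forms do not appear separately among these compounds.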